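The source may hold more compounds than are shown below. What is called first, only, known or untested is meant among the compounds shown, and "the series" means these compounds.

Measured so far in an ADME assay on Vero cells (Chlorocebus sabaeus) for cytotoxicity, read by resazurin assay, with a stated time of 72 h; on this read-out higher numbers stand for weaker inhibition and lower numbers for stronger inhibition: compound 1 `COc1ccc(C(=O)CCN2CCN(c3ccc(Cl)cc3)CC2)cc1` gives 300000 nM, compound 2 `COc1ccc(C(=O)CCN2CCN(c3ccc([N+](=O)[O-])cc3)CC2)cc1` gives 587000 nM, and compound 3 `O=C(CCN1CCN(c2ccc(Cl)cc2)CC1)c1ccc(Br)cc1` gives 52100 nM.

Compound 4 `O=C(CCN1CCN(c2ccc([N+](=O)[O-])cc2)CC1)c1ccc(Br)cc1` has not yet been measured. It differs from compound 3 by nitro in place of chloro on an aromatic carbon. The same change, (nitro in place of chloro on an aromatic carbon), has been made once before, from compound 1 to compound 2, where it gave a 2.0-fold higher number from compound 1 to compound 2 (0.29 log units; within the scatter). The two cores differ by bromo in place of methoxy on an aromatic carbon, a change that gave a 5.8-fold lower number from compound 1 to compound 3 (0.76 log units; beyond the scatter). The place of the change is the same in both pairs. For the measured compounds named here, since the one earlier instance of this change stayed within the scatter, compound 4 is expected to land near compound 3, with a step of about a 1.7-fold higher number from compound 3 to compound 4 (0.24 log units; within the scatter). The estimate for compound 4 in this assay is 90000 nM, with a likely range from 40000 nM to 200000 nM.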

Compound 4, half-maximal inhibitory concentration: 79800 nM
Compound 4: middle estimate off by 1.1-fold (0.05 log units), on the high side; low and high end bracket the measured number.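

In this assay, nitro in place of chloro gave a 1.5-fold higher number from compound 3 to compound 4 (0.19 log units; within the scatter), so the change again stayed within the scatter, and it carried over from one core to the other: the same change on two cores in this assay, a 2.0-fold higher number (0.29 log units; within the scatter) from compound 1 to compound 2 and a 1.5-fold higher number (0.19 log units; within the scatter) from compound 3 to compound 4, 1.3-fold (0.11 log units) apart, within the scatter of two such steps. Bromo in place of methoxy, with nitro present, gave a 7.4-fold lower number from compound 2 to compound 4 (0.87 log units; beyond the scatter), and this larger step also held its size: the same change on two cores in this assay, a 5.8-fold lower number (0.76 log units; beyond the scatter) from compound 1 to compound 3 and a 7.4-fold lower number (0.87 log units; beyond the scatter) from compound 2 to compound 4, 1.3-fold (0.11 log units) apart, within the scatter of two such steps. Together these four compounds show each change behaving alike on both cores, but two pairs do not show that this would hold on any further core, nor do they explain why it holds here.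

On these data alone, it stays open what an amine or a carboxylic acid would do at the same place on the ring. As far as these compounds go, the effect of a longer chain joining the carbonyl to the rest of the molecule is also open.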